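The source may hold more compounds than are shown below. What is called first, only, known or untested is meant among the compounds shown, and "the series" means these compounds.

Measured compounds so far:
Compound 1, `Cc1ccc(-c2cnc(N(CCCCOc3ccccc3)Cc3ccc(C(=O)NO)cc3)s2)cc1`, gives 10300 nM in a functional assay on PC-3 cells (Homo sapiens) for antiproliferative activity, read by MTT assay, with a stated time of 48 h; on this read-out lower numbers stand for stronger inhibition of growth and higher numbers for weaker inhibition of growth.
Compound 2, `Cc1ccc(-c2cnc(N(CCCOc3ccccc3)Cc3ccc(C(=O)NO)cc3)s2)cc1`, gives 17500 nM in this assay.

Among the compounds with values here, compound 2 holds the higher of the two numbers, but its only neighbour is compound 1, and the step of a 1.7-fold higher number from compound 1 to compound 2 (0.23 log units; within the scatter) stays within the scatter, so the two compounds cannot be set in order on this read-out. Compound 3, `Cc1ccc(-c2cnc(N(Cc3ccc(C(=O)NO)cc3)C(C)C)s2)cc1`, has not yet been measured. It differs from compound 2 in one place: isopropyl in place of 3-phenoxypropyl on a nitrogen on an aromatic ring.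

Within the data shown here, the single measured step, a 1.7-fold higher number from compound 1 to compound 2 (0.23 log units; within the scatter), concerned only the length of the chain carrying the phenoxy group and did not move the number beyond the scatter. Among the measured compounds shown here, the change to compound 3 removes that whole chain together with its ring, and no measured step speaks to such a loss; the available comparison offers no evidence for a large shift, but also none that the ring can be spared. On this thin footing compound 3 is expected to give about 28000 nM in this assay, estimated to lie between 9000 nM and 90000 nM. The expected step is therefore a 1.6-fold higher number from compound 2 to compound 3 (0.20 log units; within the scatter), leaning toward weaker inhibition of growth with wide uncertainty.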

Compound 3, concentration for 50% growth inhibition: 1150 nM
The estimate for compound 3 lay 24-fold (1.39 log units) above the measured number; measured number below the stated range.
By their numbers in this assay, from the lowest: compound 3; then compounds 1 and 2 (each within the scatter of the next).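

Going from the phenoxy-bearing chains to isopropyl on the nitrogen on an aromatic ring brings a clear gain in this assay, shown both by the step (a 15-fold lower number from compound 2 to compound 3 (1.18 log units; beyond the scatter)) and by the step (a 9.0-fold lower number from compound 1 to compound 3 (0.95 log units; beyond the scatter)). The earlier step (a 1.7-fold higher number from compound 1 to compound 2 (0.23 log units; within the scatter)) showed only that changing the chain between 3-phenoxypropyl and 4-phenoxybutyl leaves the number within the scatter, whereas compound 3 shows that this position tolerates the loss of the whole chain with its six-membered aromatic ring and its oxygen, and that growth inhibition here does not depend on that ring being present. Nothing available explains why the smaller isopropyl group gives the lower number.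

Because isopropyl differs from both chains in size, ring and oxygen at once, these compounds do not show which of these changes carries the gain, and a plain butyl chain or a benzyl group on the same nitrogen would help to separate them. They also leave open how far the trend runs toward smaller or larger groups, such as methyl, ethyl or cyclohexyl, at this position.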